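The compounds below may be only part of what the source reports. "The series", "measured", "known", "first", "only" and "open" are said of these compounds alone.

Compounds measured in a functional assay on HT-29 cells (Homo sapiens) for inhibition, read by MTT assay, with a stated time of 72 h; a lower number here means a stronger inhibitor, a higher number a weaker inhibitor:
- compound 1, `CCCNC(=C\C(=O)/C=C/c1ccc(O)c(OC)c1)/C=C/c1ccc(O)c(OC)c1`: 22700 nM
- compound 2, `C=CCNC(=C\C(=O)/C=C/c1ccc(O)c(OC)c1)/C=C/c1ccc(O)c(OC)c1`: only the assay limit, > 25000 nM
- compound 3, `CCC(C)NC(=C\C(=O)/C=C/c1ccc(O)cc1)/C=C/c1ccc(O)cc1`: 13000 nM

Compound 3 holds the lowest of the two numbers reported, but compound 1 sits so close that the two are within the usual scatter, so no order between them is claimed. Compound 2 gave no number, only the limit (the limit of > 25000 nM in this assay, at which 1 of the 3 values shown sits).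

Compound 4, `O=C(/C=C(/C=C/c1ccc(O)cc1)NC1CCCCC1)/C=C/c1ccc(O)cc1`, differs from compound 3 in one place: cyclohexyl in place of sec-butyl on an amine nitrogen. Among the measured compounds shown here, the only measured step that touches the substituent on the amine nitrogen is an at least 1.1-fold higher number from compound 1 to compound 2 (0.04 log units; that floor lies within the scatter), and that step stayed within the scatter. For the measured compounds named here, no measured pair exchanges an open chain for a carbocycle, so the present change rests on that single small step alone. The expected step of a 1.1-fold lower number from compound 3 to compound 4 (0.03 log units; within the scatter) is therefore estimated to stay within the scatter, with no direction favoured. Compound 4 is expected to give about 12000 nM in this assay, in a range from 5000 nM to 25000 nM.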

Compound 4, half-maximal inhibitory concentration: 4000 nM
For compound 4 the middle estimate is 3.0-fold (0.48 log units) above the measured one; measured number outside the range, below it.
By their numbers in this assay, from the lowest: compound 4; then compounds 3 and 1 (each within the scatter of the next). At a limit, above all of these: compound 2.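

In this assay, among the compounds shown here, the step of a 3.3-fold lower number from compound 3 to compound 4 (0.51 log units; beyond the scatter) is the first change on the amine nitrogen that is read as beyond the scatter, so this position can shift the number when sec-butyl gives way to cyclohexyl. The earlier step at this nitrogen, an at least 1.1-fold higher number from compound 1 to compound 2 (0.04 log units; that floor lies within the scatter), rests on a limit for compound 2 and showed only a floor within the scatter. No measurement shown gives a cause for the new step.

As far as these compounds go, whether the lower number follows the ring itself or simply the larger carbon substituent stays open, and an open n-hexyl chain or a cyclopentyl group on the same nitrogen would bear on that. Also open, from the compounds shown here alone, is whether cyclohexyl has the same effect on the core of compound 1, which carries methoxy groups on its aromatic rings.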